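Swapping a dichlorophenyl for a dimethoxyphenyl on the ring nitrogen

The compounds below may be only part of what the source reports. "The series", "measured", "known", "first", "only" and "open" are said of these compounds alone.

Measured compounds:
compound 1, `COc1ccc(-c2cs/c(=N\NC(=O)c3ccc(O)cc3)n2-c2ccc(OC)cc2OC)cc1`, 52500 nM
compound 2, `O=C(N/N=c1\scc(-c2ccc(Cl)cc2)n1-c1ccc(Cl)cc1Cl)c1ccc(O)cc1`, 52500 nM
compound 3, `O=C(c1ccc(O)cc1)n1nc(-c2c(Cl)cccc2Cl)sc1=S`, 57500 nM

In a functional assay on CAKI-1 cells (Homo sapiens) for cytotoxicity, read by sulforhodamine B assay, with a stated time of 48 h (a lower number here means a stronger inhibitor of growth, a higher number a weaker inhibitor of growth), compound 2 gives 52500 nM, the same digits as compound 1 and together the lowest of the three; compound 3, at 57500 nM, sits within the scatter of both, so none of the three can be set apart.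

Compound 4, `COc1ccc(-n2c(-c3ccc(Cl)cc3)cs/c2=N\NC(=O)c2ccc(O)cc2)c(OC)c1`, differs from compound 2 by 2,4-dimethoxyphenyl in place of 2,4-dichlorophenyl on an aromatic nitrogen. Compound 1 also carries 2,4-dimethoxyphenyl on an aromatic nitrogen and gives 52500 nM, indistinguishable from compound 2. No change beyond the scatter is therefore expected from compound 2 to compound 4, a step estimated as no change at the digits printed from compound 2 to compound 4 (within the scatter). Compound 4 is expected to give 52500 nM in this assay, within a range of 28000 nM to 95000 nM.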

Compound 4, concentration for total growth inhibition: < 100000 nM
Compound 4: only a limit was reported (the forecaster's own chance of this, stated with the estimate: 10%); the middle value is on the limit's open side.
By their numbers in this assay, from the lowest: compounds 1, 2 and 3 (each within the scatter of the next).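

In this assay compound 4 gives < 100000 nM as a limit only. Among these compounds, no step from compound 1 or compound 2 to compound 4 can be read: the limit of < 100000 nM in this assay, at which 1 of the 4 values shown sits. The compounds shown leave open whether 2,4-dimethoxyphenyl in place of 2,4-dichlorophenyl on an aromatic nitrogen changes growth inhibition at all.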